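From 4-Methylphenyl to 4-Bromophenyl

The source may report more compounds than this note shows. Statements on the series, on what has been measured and on what is new or still open speak of the compounds shown alone.

In a functional assay on HCT-116 cells (Homo sapiens) for antiproliferative activity, read by MTT assay, with a stated time of 72 h (on this read-out lower numbers stand for stronger inhibition and higher numbers for weaker inhibition), compound 2 (`CCOC(=O)c1csc2nc(CN3CCN(C)CC3)c(-c3ccc(C)cc3)n12`) gives 61000 nM, and compound 3 (`CCOC(=O)c1csc2nc(CN3CCN(Cc4ccccc4)CC3)c(-c3ccc(C)cc3)n12`) gives 47800 nM. Compound 1 (`COc1ccc(NC(=S)Nc2nc(C(=O)NCc3ccccc3)cs2)cc1`), with a different core, gives a lower number than both, 18200 nM. Compound 4 (`CCOC(=O)c1csc2nc(CN3CCN(C)CC3)c(-c3ccc(Br)cc3)n12`) replaces the 4-methylphenyl of compound 2 with 4-bromophenyl, placing bromo in place of methyl on an aromatic carbon. Within the data shown here, no measured step touches this carbon. The only one, a 1.3-fold lower number from compound 2 to compound 3 (0.11 log units; within the scatter), lies elsewhere in the molecule, so it offers only weak guidance, and no step beyond the scatter is expected in this assay. The estimated change is a 1.4-fold lower number from compound 2 to compound 4 (0.13 log units; within the scatter). Compound 4 is expected at 45000 nM, within an estimated range of 18000 nM to 100000 nM.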

Compound 4, half-maximal inhibitory concentration: 93600 nM
Compound 4: the middle estimate sits 2.1-fold (0.32 log units) below what was measured, and the stated range covers the measured number.
By their numbers in this assay, from the lowest: compound 1; then compounds 3, 2 and 4 (each within the scatter of the next).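

In this assay, among these compounds, a 1.5-fold higher number from compound 2 to compound 4 (0.19 log units; within the scatter) is the first measured change at this aromatic carbon, para to a large group. It shows that bromo in place of methyl here stays within the usual scatter, so this swap does not separate compound 4 from compound 2. Nothing available bears on what lies behind this result.

From the compounds shown here alone, whether an amine, a carboxylic acid or a methoxy group on this carbon would give a step beyond the scatter remains open. So does whether bromo would behave the same way on the frame of compound 3.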